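Dichloroacetamide biaryl series: fluoro to trifluoromethyl swaps

The compounds below may be only part of what the source reports. "The series", "measured", "known", "first", "only" and "open" are said of these compounds alone.

Working notes on four dichloroacetanilides sharing a biaryl core. Compound 1 `O=C(Nc1cccc(-c2ccccc2C(F)(F)F)c1)C(Cl)Cl` and compound 2 `O=C(Nc1cccc(-c2ccccc2F)c1)C(Cl)Cl` differ in one place; compound 3 `O=C(Nc1cccc(-c2ccc(F)cc2)c1)C(Cl)Cl` carries the same atoms as compound 2 joined differently, and the difference between the two cores is not broken down here. Compound 4 `O=C(Nc1cccc(-c2ccc(C(F)(F)F)cc2)c1)C(Cl)Cl` is not yet measured.

In a functional assay on KB 3-1 cells (Homo sapiens) for cytotoxicity, read by MTT assay, with a stated time of 68 h (on this read-out higher numbers stand for weaker inhibition and lower numbers for stronger inhibition), compound 1 gives 35900 nM, compound 2 gives 48300 nM and compound 3 gives 26200 nM. All three lie within the usual scatter of one another, so no order among them is claimed.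

The measured step from compound 2 to compound 1 is trifluoromethyl in place of fluoro on an aromatic carbon, and in this assay it gave a 1.3-fold lower number from compound 2 to compound 1 (0.13 log units; within the scatter). The step from compound 3 to compound 4 is trifluoromethyl in place of fluoro on an aromatic carbon. The two changes are of the same kind but not the same: in the first the entering group sits ortho to a large group, in the second para to a large group. The change has been seen only once so far.

For compound 4 the expected step in this assay is a 1.2-fold lower number from compound 3 to compound 4 (0.08 log units; within the scatter), resting on the near-flat result of a 1.3-fold lower number from compound 2 to compound 1 (0.13 log units; within the scatter) and on the value of compound 3, 26200 nM. Compound 4 is therefore estimated at 22000 nM, with the likely range running from 10000 nM to 50000 nM.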

Compound 4, half-maximal inhibitory concentration: > 50000 nM
Compound 4: a limit, no number; the forecaster's own chance of this, stated with the estimate: 5%; at least 2.2-fold (0.35 log units) between middle value and limit.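

In this assay compound 4 gives > 50000 nM, which is a limit of the assay and not a number. Trifluoromethyl in place of fluoro, para to a large group, gives an at least 1.9-fold higher number from compound 3 to compound 4 (0.28 log units; that floor lies within the scatter), and this is a floor for the step rather than its measured size. The result shows that the near-flat step seen on the core of compound 2 cannot be assumed to carry over to the core of compound 3, but it does not establish that the change behaves differently on the two cores: the same change on two cores in this assay, a 1.3-fold lower number (0.13 log units; within the scatter) from compound 2 to compound 1 and an at least 1.9-fold higher number (0.28 log units; that floor lies within the scatter) from compound 3 to compound 4; the limit leaves it open whether they differ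

On these data alone, the true size of the step to compound 4 stays open, since only its floor can be read: the limit of > 50000 nM in this assay, at which 1 of the 4 values shown sits. Also open is whether an amine, a nitrile, a methoxy group or a carboxylic acid in place of fluoro on the same aromatic carbon would give a readable value in this assay, and whether the trifluoromethyl steps would look the same with a longer acyl chain in place of the dichloroacetyl group.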